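Nitro in Place of Trifluoromethyl on a Piperidine Scaffold

The compounds below may be only part of what the source reports. "The series", "measured", "known", "first", "only" and "open" are said of these compounds alone.

Three compounds have been examined in an assay for inhibition of protein disulfide-isomerase (Homo sapiens), with a stated time of 1 h; on this read-out higher numbers stand for weaker inhibition and lower numbers for stronger inhibition. Compound 2 `Oc1ccc2[nH]ncc2c1C(c1ccc(C(F)(F)F)cc1)N1CCCCC1` gives 710 nM. Compound 1 `Oc1cc(F)ccc1C(c1ccc2ccoc2c1O)N1CCCCC1` gives 1070 nM; of the two numbers shown, that of compound 2 is the smaller, but the gap to compound 1 lies within the scatter, so the two cannot be separated. Compound 3 `Cc1ccnc(NC(c2cc(C)ccc2C)c2ccc3cccnc3c2O)c1` is reported only as a limit, > 40000 nM, and so carries no number; (the limit of > 40000 nM in this assay, at which 1 of the 3 values shown sits).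

Compound 4 `O=[N+]([O-])c1ccc(C(c2c(O)ccc3[nH]ncc23)N2CCCCC2)cc1` keeps the core of compound 2 and differs in one place: nitro in place of trifluoromethyl on an aromatic carbon, a nitro in place of trifluoromethyl on an aromatic carbon, para to a large group. For the measured compounds named here, no measured pair shows this exchange, so its size must be judged without a precedent. The step of a 1.3-fold higher number from compound 2 to compound 4 (0.10 log units; within the scatter) is expected to stay within the scatter, with no clear direction. In this assay compound 4 is therefore estimated to give about 900 nM, with a range from 300 nM to 3000 nM.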

Compound 4, half-maximal inhibitory concentration: 520 nM
Compound 4: the middle estimate sits 1.7-fold (0.24 log units) above what was measured; the range from low to high includes it.
By their numbers in this assay, from the lowest: compounds 4, 2 and 1 (each within the scatter of the next, the first and the last beyond it). At a limit, above all of these: compound 3.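

Nitro in place of trifluoromethyl on an aromatic carbon, para to a large group, is the first exchange at this position that can be read: in this assay it amounts to a 1.4-fold lower number from compound 2 to compound 4 (0.14 log units; within the scatter) and so leaves the two compounds inseparable. The earlier compounds shown here offered no pair of this kind, and this one shows that on the core of compound 2 the number stays within the scatter when trifluoromethyl, with no hydrogen-bond acceptor, gives way to nitro, with 2 of them. No measurement shown here bears on why the step is this small.

From the compounds shown here alone, whether this holds for other groups at this position stays open, for instance an amine, a carboxylic acid or a longer chain. Also open, going by these compounds, is whether the same exchange would behave alike on the core of compound 1.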